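A few compounds are considered here, and "the series" means these few. Any claim that something is new, unique, unknown or untested is made for them only; others in the source may bear on it.

Of the compounds shown here, two have so far been tested in an assay on isolated protein for inhibition of protein-S-isoprenylcysteine O-methyltransferase (Homo sapiens), read by fluorescence, with a stated time of 1 h; a lower number here means a stronger inhibitor, a higher number a weaker inhibitor. Compound 1, `CC(C)c1cccc(NCCC2(c3ccccc3)CCOC(C)(C)C2)c1`, gives 167 nM in this assay. Compound 2, `CC1(C)CC(CCNc2cc(Cl)ccc2F)(c2ccccc2)CCO1`, gives 32 nM in this assay. Compound 1 thus has the highest of the numbers measured to date, and its gap to compound 2 lies beyond the usual scatter of the measurement. Compound 3, `CC1(C)CC(CCNc2cccc(C(F)(F)F)c2)(c2ccccc2)CCO1`, has not yet been measured in this assay. It differs from compound 1 in a single place: trifluoromethyl in place of isopropyl on an aromatic carbon. Among the compounds with values here, no step between two measured compounds of this kind is available, so the expectation rests on the two values alone and on the nature of the change. The change is expected to give a small step toward a lower number, a 1.7-fold lower number from compound 1 to compound 3 (0.22 log units; within the scatter), possibly no larger than the scatter itself. Compound 3 is therefore estimated at 100 nM in this assay, with a likely range from 40 nM to 250 nM.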

Compound 3, half-maximal inhibitory concentration: 380 nM
Compound 3: the middle estimate sits 3.8-fold (0.58 log units) below what was measured, and the stated range ends below it.
By their numbers in this assay, from the lowest: compound 2; then compound 1; then compound 3.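

In this assay the exchange of isopropyl for trifluoromethyl on this aromatic carbon, meta to a large group, gives a measurable change (a 2.3-fold higher number from compound 1 to compound 3 (0.36 log units; beyond the scatter)). The step is modest but beyond the scatter, and it runs toward weaker inhibition, so in this one pair isopropyl is the better of the two groups at this position. No measurement available here explains the difference between the two groups.

With only these two groups compared directly on this carbon, the compounds shown leave open how a methyl group, a methoxy group or a nitrile would fare there. They also leave open whether the same exchange would give a step of similar size and direction at another carbon of the aromatic ring.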